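A Single Group Exchange Starting From Compound 2

A few compounds are considered here, and "the series" means these few. Any claim that something is new, unique, unknown or untested is made for them only; others in the source may bear on it.

- compound 1 `CCOC(=O)C1=C(N/N=C(\c2ccc([N+](=O)[O-])cc2)N2CCN(c3ccc(F)cc3)CC2)Nc2[nH]nc(C)c2C1c1ccc(N(C)C)cc1`: 90200 nM
- compound 2 `CCOC(=O)C1=C(NN=C(C#N)C#N)Nc2[nH]nc(C)c2C1c1ccc(N(C)C)cc1`: 13700 nM
- compound 3 `CCOC(=O)C1=C(N/C=N/c2ncc(-c3ccccc3)s2)Nc2[nH]nc(C)c2C1c1ccc(N(C)C)cc1`: 9790 nM

These three compounds share a core and were all tested in a functional assay on HepG2 cells (Homo sapiens) for inhibition, read by MTT assay, with a stated time of 48 h; a lower number here means a stronger inhibitor, a higher number a weaker inhibitor. In this assay compound 2 stands at 13700 nM, within the usual scatter of compound 3 at 9790 nM. Compound 1 gives 90200 nM, a number beyond the scatter from both of the others, and so compound 2 is the clearly stronger inhibitor of that pair.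

Compound 4 `CCOC(=O)C1=C(N/N=C(/Cl)C#N)Nc2[nH]nc(C)c2C1c1ccc(N(C)C)cc1` has not yet been measured. It departs from compound 2 in one place, on an amine nitrogen: a group of 5 heavy atoms (2 carbon, 2 nitrogen, 1 chlorine; no ring) in place of a group of 6 heavy atoms (3 carbon, 3 nitrogen; no ring), on an amine nitrogen. The three measured compounds differ from one another too widely to show what this exchange does, so no direct guide exists. The expectation therefore rests on compound 2 at 13700 nM as the closest measured structure. In this assay no change beyond the scatter is expected in either direction, and the estimated step is a 1.1-fold lower number from compound 2 to compound 4 (0.06 log units; within the scatter). For compound 4 the estimated value is 12000 nM, with an expected range from 5000 nM to 30000 nM.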

Compound 4, half-maximal inhibitory concentration: 23600 nM
The estimate for compound 4 lay 2.0-fold (0.29 log units) below the measured number; the range from low to high includes it.
By their numbers in this assay, from the lowest: compounds 3, 2 and 4 (each within the scatter of the next, the first and the last beyond it); then compound 1.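

In this assay, within the data shown here, the exchange on the amine nitrogen gives the first reading of a single change: a 1.7-fold higher number from compound 2 to compound 4 (0.24 log units; within the scatter), a step that lies within the usual scatter. A group of 5 heavy atoms (2 carbon, 2 nitrogen, 1 chlorine; no ring) can therefore stand in place of a group of 6 heavy atoms (3 carbon, 3 nitrogen; no ring) at this position without a change that this assay can separate from repeat variation. The earlier compounds shown here differed too widely to show this.

From the compounds shown here alone, the effect of a group of another kind on this amine nitrogen, such as a carboxylic acid or a primary amine, remains open. No measurement bearing on the reason for this result is available here.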